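Working notes: from compound 2 to compound 3

The compounds below may be only part of what the source reports. "The series", "measured", "known", "first", "only" and "open" are said of these compounds alone.

Measured so far in a physicochemical assay for lipophilicity, read by LC-MS, using the shake flask method, in phosphate buffer, measured as octanol-water partition, with a stated time of 2 h, at pH 7.4; a lower number here means a more polar compound, a higher number a more lipophilic compound
- compound 1 `O=C(O)c1ccc(-n2cc(CO[C@H]3O[C@H](CO)[C@@H](O)[C@H](O)[C@@H]3O)nn2)cc1` gives "not determined" (no result reported)
- compound 2 `COc1ccc(Cn2cc(CO[C@H]3O[C@H](CO)[C@@H](O)[C@H](O)[C@@H]3O)nn2)cc1` gives -0.4

Among the measured compounds shown here, compound 2 at -0.4 carries the only number, so nothing measured ranks it. Compound 3 (`OC[C@H]1O[C@H](OCc2cn(-c3ccc(F)cc3)nn2)[C@@H](O)[C@@H](O)[C@@H]1O`) awaits measurement. The change 4-fluorophenyl in place of 4-methoxybenzyl on an aromatic nitrogen puts 4-fluorophenyl in place of 4-methoxybenzyl on an aromatic nitrogen. For the measured compounds named here, no measured step guides the size of the shift in this assay here, so this expectation rests on the structural change alone. The expected step of a number 0.20 log units higher from compound 2 to compound 3 (within the scatter) is small, upward and within the usual scatter. The estimate for compound 3 is -0.2 (expected range -0.6 to 0.2).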

Compound 3, distribution coefficient: -0.15
Beside the measured number, compound 3's estimate is 0.05 log units below it; the range from low to high includes it.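

In this assay, 4-fluorophenyl in place of 4-methoxybenzyl on an aromatic nitrogen gives a number 0.25 log units higher from compound 2 to compound 3 (within the scatter). Among the compounds shown here, this is the first step read at this position, and it shows that this exchange of groups, which also removes a hydrogen-bond acceptor from the substituent, leaves the two compounds indistinguishable in this read-out. Nothing available bears on why the exchange gives this result.

A single step cannot show how other groups on this aromatic nitrogen would behave. As far as these compounds go, what an amine or a longer chain there would give remains open.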